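The compounds below may be only part of what the source reports. "The series", "measured", "known", "first", "only" and "open" are said of these compounds alone.

Among the measured compounds shown here, compound 2 `C[C@H]1CC[C@@H]2[C@@H](OC(=O)[C@]23CC(c2ccc([N+](=O)[O-])cc2)=NO3)[C@]2(C)C(=O)C=C[C@@]12O` is one of three compounds measured in a functional assay on SW-620 cells (Homo sapiens) for cytotoxicity, read by sulforhodamine B assay, with a stated time of 48 h; a lower number here means a stronger inhibitor, a higher number a weaker inhibitor. Compound 2 gives 9000 nM. Compound 3 `C[C@H]1CC[C@@H]2[C@@H](OC(=O)[C@]23CC(c2ccccc2Cl)=NO3)[C@]2(C)C(=O)C=C[C@@]12O` gives 9000 nM, and the step is no change at the digits printed from compound 2 to compound 3 (within the scatter). Compound 1 `COc1ccc(C2=NO[C@]3(C2)C(=O)O[C@@H]2[C@H]3CC[C@H](C)[C@]3(O)C=CC(=O)[C@@]23C)cc1` gives 41000 nM; the step is a 4.6-fold lower number from compound 1 to compound 2 (0.66 log units; beyond the scatter), and likewise a 4.6-fold lower number from compound 1 to compound 3 (0.66 log units; beyond the scatter). For the measured compounds named here, compound 2 thus stands with compound 3 at the lowest numbers of the three, with compound 1 the only compound beyond the scatter from it.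

Compound 4 `C[C@H]1CC[C@@H]2[C@@H](OC(=O)[C@]23CC(c2ccc(C#N)cc2)=NO3)[C@]2(C)C(=O)C=C[C@@]12O` differs from compound 2 by cyano in place of nitro on an aromatic carbon. Going by the values given here, no measured step exchanges nitro for cyano. The step of a 4.6-fold lower number from compound 1 to compound 2 (0.66 log units; beyond the scatter) shows that replacing the group on this aromatic carbon can move the number beyond the scatter, whereas the step of no change at the digits printed from compound 2 to compound 3 (within the scatter) shows that a further change of the aryl group left the number unchanged. Both groups carry the same place on the ring, so the expected step in this assay is a 1.1-fold higher number from compound 2 to compound 4 (0.05 log units; within the scatter), not beyond the scatter. Compound 4 is estimated at 10000 nM, within the range 4000 nM to 30000 nM.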

Compound 4, half-maximal inhibitory concentration: 53000 nM
Estimate against measurement, compound 4: 5.3-fold (0.72 log units) below; measured number above the stated range.
By their numbers in this assay, from the lowest: compounds 2 and 3 (each within the scatter of the next); then compounds 1 and 4 (each within the scatter of the next).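

In this assay, cyano and nitro are not interchangeable on this aromatic carbon, para to a large group: the step is a 5.9-fold higher number from compound 2 to compound 4 (0.77 log units; beyond the scatter) and goes beyond the scatter, and the comparison with the 2-chlorophenyl group gives a 5.9-fold higher number from compound 3 to compound 4 (0.77 log units; beyond the scatter) on the same scale. Cyano instead falls level with methoxy, with a 1.3-fold higher number from compound 1 to compound 4 (0.11 log units; within the scatter) lying within the scatter, so a shared place on the ring did not give nitro and cyano a shared number, and the three compounds with a group at this place divide into nitro on one side and methoxy and cyano on the other. Nothing available explains this division.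

The compounds shown leave open where other groups on this carbon would fall, such as an amine or a carboxylic acid. They also leave open whether a chloro group at this same place would stay level with nitro.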